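A few compounds are considered here, and "the series" means these few. Any claim that something is new, unique, unknown or untested is made for them only; others in the source may bear on it.

Compound 1 `COc1ccc(/C=N/NC(=O)CSc2nnc(-c3ccncc3)o2)cc1` gives 19800 nM in a functional assay on BGC-823 cells (Homo sapiens) for cytotoxicity, read by MTT assay, with a stated time of 48 h; a lower number here means a stronger inhibitor, a higher number a weaker inhibitor.
Compound 2 `O=C(CSc1nnc(-c2ccncc2)o1)N/N=C/c1cc(Br)cc(Br)c1O` gives 9610 nM in this assay.

Compound 2 has the lowest number of the two, separated from compound 1 by a 2.1-fold lower number from compound 1 to compound 2 (0.31 log units; beyond the scatter). Compound 3 `O=C(CSc1nnc(-c2ccncc2)o1)N/N=C/c1ccc(O)c(O)c1` differs from compound 2 in one place: 3,4-dihydroxyphenyl in place of 3,5-dibromo-2-hydroxyphenyl on a carbon with a double bond to nitrogen. Going by the values given here, the only step that bears on this is the one from compound 1 to compound 2, which also swapped the group on that carbon and moved the number by a modest amount. A change of similar or smaller size is expected for compound 3, in no clear direction. The expected step is a 1.2-fold higher number from compound 2 to compound 3 (0.10 log units; within the scatter). Compound 3 is estimated at 12000 nM, within 5000 nM to 30000 nM.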

Compound 3, half-maximal inhibitory concentration: 1260 nM
Beside the measured number, compound 3's estimate is 9.5-fold (0.98 log units) above it; measured number outside the range, below it.
By their numbers in this assay, from the lowest: compound 3; then compound 2; then compound 1.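

In this assay this position proves far more sensitive than the earlier step suggested: 3,4-dihydroxyphenyl in place of 3,5-dibromo-2-hydroxyphenyl gives a 7.6-fold lower number from compound 2 to compound 3 (0.88 log units; beyond the scatter), and in place of 4-methoxyphenyl it gives a 16-fold lower number from compound 1 to compound 3 (1.20 log units; beyond the scatter). The group on this carbon can therefore move the number strongly, and the 3,4-dihydroxyphenyl group gives the lowest of the three numbers. No measurement at hand explains this difference. Still open, as far as these compounds go, is whether both hydroxy groups are needed, and whether a phenyl ring carrying an amine or a carboxylic acid instead would match compound 3.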